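The source may report more compounds than this note shows. Statements on the series, on what has been measured and on what is new or still open speak of the compounds shown alone.

Two compounds of this series carry a measurement so far. Compound 1 `COc1cccc(CN2C(=O)CN(C(=O)c3cc4cc(OC)ccc4o3)C[C@@H]2CCc2ccccc2)c1` gives 0.128 h in an ADME assay on microsomes from liver (Homo sapiens) for metabolic stability, with a stated time of 30 min, tested at 1 uM; a lower number here means that the compound disappears faster, a higher number that the compound lasts longer. Compound 2 `COc1ccc2[nH]c(C(=O)N3CC(=O)N(Cc4ccccc4)[C@@H](CCc4ccccc4)C3)cc2c1` gives 0.167 h in this assay, the higher of the two numbers, though the gap to compound 1 lies within the scatter. Compound 3 `COc1ccc2[nH]c(C(=O)N3CC(=O)N(Cc4ccccc4)[C@@H](COc4ccccc4)C3)cc2c1` is not yet measured. It differs from compound 2 in one place: phenoxy in place of benzyl on a saturated chain carbon bound to a saturated ring carbon. Within the data shown here, no measured pair shows this exchange, so no direction beyond the scatter is expected. The step expected here is a 1.0-fold higher number from compound 2 to compound 3 (0.01 log units; within the scatter). Compound 3 is thus expected to give 0.17 h in this assay, with a range from 0.08 h to 0.35 h.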

Compound 3, half-life: 0.65 h
Estimate against measurement, compound 3: 3.8-fold (0.58 log units) below; measured number outside the range, above it.
By their numbers in this assay, from the lowest: compounds 1 and 2 (each within the scatter of the next); then compound 3.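

On a saturated chain carbon bound to a saturated ring carbon, phenoxy in place of benzyl gives a 3.9-fold higher number from compound 2 to compound 3 (0.59 log units; beyond the scatter) in this assay, the first step in the series shown to lie beyond the scatter. This position therefore matters for the read-out, even though the two groups match in heavy-atom count and differ in that phenoxy brings one hydrogen-bond acceptor. No data shown here explain the step. Going by these compounds, it remains open whether a longer chain carrying the phenoxy, or an amine at this position, would retain the step. On these data alone, whether the same exchange gives a similar step on the core of compound 1 is also open.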